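Ester-linked aryl series: cytotoxicity limits and a naphthyl variant

The source may hold more compounds than are shown below. What is called first, only, known or untested is meant among the compounds shown, and "the series" means these compounds.

Measured compounds:
compound 1 `O=C(c1cn(-c2ccccc2)nc1-c1cccnc1)N1CCC(Cc2ccccc2)CC1`: > 100000 nM (a limit)
compound 2 `CC(C)c1cccc(OC(=O)c2cn(-c3ccccc3)nc2-c2cccnc2)c1`: > 100000 nM (a limit)
compound 3 `O=C(Oc1ccc(-c2ccccc2)cc1)c1cn(-c2ccccc2)nc1-c1cccnc1`: > 100000 nM (a limit)

In a functional assay on MDA-MB-231 cells (Homo sapiens) for cytotoxicity, read by MTT assay, with a stated time of 48 h (a higher number here means a weaker inhibitor, a lower number a stronger inhibitor), compound 2 gives only a limit, > 100000 nM. The same holds for compound 1 and for compound 3, so compound 2 stands at the same limit as the rest of the series, with no number to rank it against; this is the limit of > 100000 nM in this assay, at which 3 of the 3 values shown sit. The step to compound 4 `O=C(Oc1ccc2ccccc2c1)c1cn(-c2ccccc2)nc1-c1cccnc1` is naphthalen-2-yl in place of 3-isopropylphenyl on an oxygen next to a carbonyl group. Among the measured compounds shown here, no step between measured compounds is available to size this change; given that every measured value in this assay is a limit, no movement beyond the scatter is expected. Compound 4 is therefore expected to sit at about 100000 nM (range 30000 nM to 300000 nM), a step of a number no higher from compound 2 to compound 4 (the limit leaves the size open) that is itself an estimate.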

Compound 4, half-maximal inhibitory concentration: > 100000 nM
Compound 4: a limit, no number; the forecaster's own chance of this, stated with the estimate: 80%; the middle value lies on the limit itself.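

Compound 2 and compound 4 are both recorded only as limits, so no step can be read between them. The compounds shown leave open how naphthalen-2-yl and 3-isopropylphenyl compare, and which change to this series would give a measurable value.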